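The compounds below may be only part of what the source reports. "The series", "measured", "known", "first", "only" and "open" are said of these compounds alone.

Compound 2 `Cc1cc(C)nc(N2CCN(c3ccn4c(CC(F)(F)F)cnc4c3C#N)CC2)n1` and compound 1 `CCCCn1ccc(N2CCN(c3nc(C)cc(C)n3)CC2)c(C#N)c1=O` share a common core. In a functional assay on CHO cells with metabotropic glutamate receptor 2 (Homo sapiens) as the target, read by GTPgammaS binding (a lower number here means a smaller maximal response, a higher number a larger maximal response), compound 1 gives 235%, while compound 2 gives 128%, the lower of the two numbers, a gap that lies beyond the usual scatter. Compound 3 `CCCc1cnc2c(C#N)c(N3CCN(c4nc(C)cc(C)n4)CC3)ccn12` differs from compound 2 in one place: ethyl in place of trifluoromethyl on a saturated chain carbon bound to an aromatic carbon. Among the measured compounds shown here, no measured pair shows this change, so its effect here is unknown. The step expected in this assay is a number 12 percentage points higher from compound 2 to compound 3 (beyond the scatter), a small rise at most, possibly none beyond the scatter. The value expected for compound 3 is 140%, with a range from 90% to 210%.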

Compound 3, largest response reached (Emax), in percent of the reference or control that the assay uses: 179%
For compound 3 the middle estimate is 39 percentage points below the measured one; measured number inside the range.
By their numbers in this assay, from the lowest: compound 2; then compound 3; then compound 1.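

In this assay, the group on a saturated chain carbon bound to an aromatic carbon clearly matters: replacing trifluoromethyl with ethyl there gives a number 51 percentage points higher from compound 2 to compound 3 (beyond the scatter) and thus a large step. The propyl chain of compound 3 therefore gives a larger maximal response than the 2,2,2-trifluoroethyl chain of compound 2. Nothing shown here explains this step. As far as these compounds go, whether a longer chain, an amine or a carboxylic acid at this place would raise or lower the response remains open.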